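Cytotoxicity notes: aryl replacement on the ester compound

A few compounds are considered here, and "the series" means these few. Any claim that something is new, unique, unknown or untested is made for them only; others in the source may bear on it.

Compound 1 `CC(C)N(Cc1cccc(OCCCCCC(=O)O)c1)C(=O)c1ccc(-c2ccco2)cc1`: in an ADME assay on HEK293 cells (Homo sapiens) for cytotoxicity, read by CellTiter-Glo and resazurin assay, with a stated time of 72 h (a higher number here means that more compound is needed for the effect, a lower number that less compound is needed), compound 1 gives > 26000 nM, a limit of the assay.
Compound 2 `CC(C)N(Cc1cccc(OCCCCCC(=O)O)c1)C(=O)c1ccc(-c2cccc(S(C)(=O)=O)c2)cc1`: in this assay compound 2 gives > 26000 nM, a limit.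
Compound 3 `CCOC(=O)CCCCCOc1cccc(CN(C(=O)c2ccc(-c3ccco3)cc2)C(C)C)c1`: in this assay compound 3 gives > 26000 nM, a limit.

Compound 3 thus stands at the limit where all three measured compounds sit (the limit of > 26000 nM in this assay, at which 3 of the 3 values shown sit); no number separates it from compound 1 or compound 2. The unmeasured compound 4 `CCOC(=O)CCCCCOc1cccc(CN(C(=O)c2ccc(-c3cccc(OC(F)(F)F)c3)cc2)C(C)C)c1` differs from compound 3 by 3-(trifluoromethoxy)phenyl in place of furan-2-yl on an aromatic carbon.

The measured steps that touch the same regions are a step that the two limits leave unreadable from compound 1 to compound 2 and a step that the two limits leave unreadable from compound 1 to compound 3; neither gives a readable size, so no direction can be drawn from them. Since every aryl variant so far returns only a limit, compound 4 is expected to do the same, the estimated step being a number no higher from compound 3 to compound 4 (the limit leaves the size open). The expected value for compound 4 in this assay is 26000 nM, within 10000 nM to 60000 nM.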

Compound 4, half-maximal effective concentration: > 26000 nM
Compound 4 ended at the assay's limit; the forecaster's own chance of this, stated with the estimate: 80%; the middle value lies on the limit itself.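

Among the compounds shown here, compound 3 and compound 4 both return only a limit, so no step between them can be read. The compounds shown leave open the concentration at which any of them acts in this assay, and whether the aryl replacement matters there.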